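A few compounds are considered here, and "the series" means these few. Any claim that something is new, unique, unknown or untested is made for them only; others in the source may bear on it.

The measured compounds:
Compound 1, `N#Cc1ccc(NC(=O)c2ccc(Cl)cc2O)cc1`, gives 1300 nM in a functional assay on HL-60 cells (Homo sapiens) for cytotoxicity, read by luminescence and CellTiter-Glo, with a stated time of 3 days; on this read-out higher numbers stand for weaker inhibition and lower numbers for stronger inhibition.
Compound 2, `N#Cc1ccc(NC(=O)c2ccc(-c3cccnc3)cc2O)cc1`, gives 6660 nM in this assay.
Compound 3, `N#Cc1ccc(NC(=O)c2cc(-c3cccnc3)ccc2O)cc1`, gives 7960 nM in this assay.

Compounds 2 and 3 hold the same atoms joined differently; how the two cores differ is not broken down here, and their two values lie within the scatter of each other. One change separates compound 2 from compound 1: chloro in place of pyridin-3-yl on an aromatic carbon. That change gave a 5.1-fold lower number from compound 2 to compound 1 (0.71 log units; beyond the scatter).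

Compound 4, `N#Cc1ccc(NC(=O)c2cc(Cl)ccc2O)cc1`, is not yet measured. It arises from compound 3 by the same kind of change: chloro in place of pyridin-3-yl on an aromatic carbon. The surroundings differ, though: here the chloro sits meta to a large group and para to a hydroxy group, whereas in compound 1 it sits meta to a hydroxy group and para to a large group. A step of similar size is expected, a 4.7-fold lower number from compound 3 to compound 4 (0.67 log units; beyond the scatter), because the same kind of change gave a 5.1-fold lower number from compound 2 to compound 1 (0.71 log units; beyond the scatter). Compound 4 is therefore expected to give 1700 nM in this assay, with a likely range from 700 nM to 4500 nM.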

Compound 4, half-maximal inhibitory concentration: 700 nM
Beside the measured number, compound 4's estimate is 2.4-fold (0.39 log units) above it; low and high end bracket the measured number.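

In this assay, chloro in place of pyridin-3-yl gave an 11-fold lower number from compound 3 to compound 4 (1.06 log units; beyond the scatter). The change lowers the number on both cores, and the two step sizes cannot be told apart: the same change on two cores in this assay, a 5.1-fold lower number (0.71 log units; beyond the scatter) from compound 2 to compound 1 and an 11-fold lower number (1.06 log units; beyond the scatter) from compound 3 to compound 4, 2.2-fold (0.35 log units) apart, within the scatter of two such steps
Within the data shown here, this rests on only two pairs of compounds, and it does not show why the number falls or whether the step would carry over to any other core.

The compounds shown carry only chloro or pyridin-3-yl on this aromatic carbon, which leaves open how a methyl group, an amine or a carboxylic acid there would compare. As far as these compounds go, all of them also keep the hydroxy group and the nitrile, so what replacing either one would do remains open too.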